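Hexafluorocarbinol phenols: amide variation toward compound 4

This account rests on a few compounds, and the source may have more. Where it says the series, first, only, none or still open, it means among the compounds named here.

Measured so far:
compound 1 `Oc1ccc(-c2ccccc2)cc1C(O)(C(F)(F)F)C(F)(F)F` gives > 500000 nM in an assay on isolated protein for inhibition of receptor-type tyrosine-protein phosphatase C (Homo sapiens), read by spectrophotometry; a higher number here means a weaker inhibitor, a lower number a stronger inhibitor
compound 2 `COc1ccc(CNC(=O)COc2ccc3cc(C(O)(C(F)(F)F)C(F)(F)F)c(O)cc3c2)cc1OC` gives > 20000 nM
compound 3 `Oc1cc(-c2ccccc2)ccc1C(O)(C(F)(F)F)C(F)(F)F` gives > 500000 nM

The value of compound 2 is a limit of this assay, not a number, and it sits at the limit of > 20000 nM in this assay, at which 1 of the 3 values shown sits. The value of compound 1 is likewise a limit, at the limit of > 500000 nM in this assay, at which 2 of the 3 values shown sit. The value of compound 3 is the same kind of limit. Within the data shown here, no step between measured compounds is available, so nothing shows how far any change moves the read-out.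

Compound 4 `CCN(CC)C(=O)COc1ccc2cc(C(O)(C(F)(F)F)C(F)(F)F)c(O)cc2c1` differs from compound 2 by diethylamino in place of (3,4-dimethoxybenzyl)amino on a carbonyl carbon. Compound 2 gives only a limit. Compound 4 is therefore expected to remain weak in this assay, with the step that the limit leaves unreadable from compound 2 to compound 4 expected to be none beyond the scatter. For compound 4 the estimate is 60000 nM, ranging from 15000 nM to 500000 nM.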

Compound 4, half-maximal inhibitory concentration: > 20000 nM
Compound 4 was reported as a limit (the forecaster's own chance of this, stated with the estimate: 70%); the middle value is on the limit's open side.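

Among these compounds, compound 2 and compound 4 are both reported only as limits, so no step between them can be read. The compounds shown leave open how far changing the amide group moves the read-out.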